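The source may hold more compounds than are shown below. What is called first, only, known or untested is meant among the compounds shown, and "the series" means these compounds.

In a functional assay on the whole organism with Mus musculus as the target (on this read-out lower numbers stand for an effect already at smaller amounts and higher numbers for an effect only at larger amounts of compound), compound 1 (`C[C@@H](NCc1ccc(Oc2ccccc2)cc1)C(N)=O`) gives 64 mg/kg and compound 2 (`C[C@@H](NCc1ccc(OCc2ccccc2Cl)cc1)C(N)=O`) gives 17.4 mg/kg as its number. Compound 3 (`C[C@@H](NCc1ccc(OCc2ccc(F)cc2)cc1)C(N)=O`) stands highest of the three (132 mg/kg). Compound 4 (`C[C@@H](NCc1ccc(OCc2ccccn2)cc1)C(N)=O`) carries pyridin-2-yl in place of 4-fluorophenyl on a saturated chain carbon bound to an oxygen on an aromatic ring. Going by the values given here, only one measured step bears on this place (a 7.6-fold higher number from compound 2 to compound 3 (0.88 log units; beyond the scatter)), and it shows that the group there matters in this assay but involves no ring with a hetero atom. With compound 3 at the top of the measured range (132 mg/kg), a modest move toward a lower number is expected in this assay. The expected step is modest (a 2.2-fold lower number from compound 3 to compound 4 (0.34 log units; beyond the scatter)). For compound 4 the estimated value is 60 mg/kg (expected range 20 mg/kg to 170 mg/kg).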

Compound 4, dose for half-maximal effect: 172 mg/kg
For compound 4 the middle estimate is 2.9-fold (0.46 log units) below the measured one, and the stated range ends below it.
By their numbers in this assay, from the lowest: compound 2; then compound 1; then compounds 3 and 4 (each within the scatter of the next).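

Putting pyridin-2-yl, a ring with a hetero atom, in place of 4-fluorophenyl on this saturated chain carbon leaves the number within the scatter (a 1.3-fold higher number from compound 3 to compound 4 (0.11 log units; within the scatter)). Set against 2-chlorophenyl, the same group gives a clear rise (a 9.9-fold higher number from compound 2 to compound 4 (0.99 log units; beyond the scatter)), and (pyridin-2-yl)methyl in place of phenyl on the oxygen also gives a rise beyond the scatter (a 2.7-fold higher number from compound 1 to compound 4 (0.43 log units; beyond the scatter)). No measurement at hand accounts for these differences. From the compounds shown here alone, whether 4-chlorophenyl or 2-fluorophenyl at this place would bring the number back toward that of compound 2 remains open.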